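This account rests on a few compounds, and the source may have more. Where it says the series, first, only, none or still open, it means among the compounds named here.

Measured compounds:
- compound 1, `COc1cc(N2CCC(C(=O)N3CCC(N(C)C)C3)CC2)ccc1Nc1nc(NC2CCCCC2)c2nc[nH]c2n1`: 38000 nM
- compound 2, `COc1cc(N2CCC(C(=O)N3CCOCC3)CC2)ccc1Nc1nc(NC2CCCCC2)c2nc[nH]c2n1`: 19000 nM

Both compounds share one core and differ only in the amide substituent. Among the measured compounds shown here, the one step measured so far, a 2.0-fold lower number from compound 1 to compound 2 (0.30 log units; within the scatter), replaces 3-(dimethylamino)pyrrolidin-1-yl with morpholin-4-yl on the carbonyl carbon, and the two numbers sit within the scatter of each other, so nothing can be said about an order between compound 1 and compound 2 in a physicochemical assay for solubility, measured as kinetic solubility, at pH 7.4; on this read-out higher numbers stand for higher solubility and lower numbers for lower solubility.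

Compound 3, `COc1cc(N2CCC(CC(=O)N3CCN(C)CC3)CC2)ccc1Nc1nc(NC2CCCCC2)c2nc[nH]c2n1`, is not yet measured. It differs from compound 2 by ((4-methylpiperazin-1-yl)carbonyl)methyl in place of (morpholin-4-yl)carbonyl on a saturated ring carbon. The change brings a 4-methylpiperazin-1-yl group onto the carbonyl and inserts a methyl between the carbonyl and the saturated ring carbon. For the measured compounds named here, the only step that bears on it is the one from compound 1 to compound 2, which stayed within the scatter; the amide substituent has so far moved this assay little. Compound 3 is therefore expected to give about 32000 nM, between 14000 nM and 75000 nM, a step of a 1.7-fold higher number from compound 2 to compound 3 (0.23 log units; within the scatter) that is not expected to exceed the scatter.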

Compound 3, solubility: 38000 nM
Beside the measured number, compound 3's estimate is 1.2-fold (0.07 log units) below it; the range from low to high includes it.
By their numbers in this assay, from the lowest: compounds 2, 1 and 3 (each within the scatter of the next).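

In this assay the place on the saturated ring carbon, three ring bonds from the ring nitrogen, now takes a change of a different kind, one that alters the group on the carbonyl and the link to the ring in a single step: ((4-methylpiperazin-1-yl)carbonyl)methyl in place of (morpholin-4-yl)carbonyl gives a 2.0-fold higher number from compound 2 to compound 3 (0.30 log units; within the scatter) and so stays inside the scatter. Set against the (3-(dimethylamino)pyrrolidin-1-yl)carbonyl group, the same entering group gives no change at the digits printed from compound 1 to compound 3 (within the scatter), so the three groups at this place cannot be put in any order on this read-out, even with the longer link included. No measurement shown here offers an explanation for this result.

The compounds shown leave open how the 4-methylpiperazin-1-yl group and the longer link would each read alone, as the two arrive together in compound 3. Also open, going by these compounds, is whether a group of another kind at this place, such as a carboxylic acid or a primary amine on a longer chain, would in this assay give a step beyond the scatter.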